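Working notes: chloro in place of hydrogen, compound 3 to compound 4

This account rests on a few compounds, and the source may have more. Where it says the series, first, only, none or still open, it means among the compounds named here.

Measured compounds:
compound 1 `CC(=O)c1c(NNc2ccc(Br)cc2)cc(C)oc1=O`: 40.4%
compound 2 `CC(=O)c1c(NNc2nc(-c3ccccc3)cs2)cc(C)oc1=O`: 45.5%
compound 3 `Cc1cc2nn(-c3ccccc3)c(C)c2c(=O)o1`: 52.5%

In a functional assay on the whole organism for inhibition, with Rattus norvegicus as the target, read by paw edema, with a stated time of 3 h, at a dose of 50 mg/kg (on this read-out higher numbers stand for more inhibition at the one dose given (going by the name of the read-out) and lower numbers for less inhibition), compound 1 gives 40.4%, compound 2 gives 45.5%, and compound 3 gives 52.5%. Compound 3 stands highest of the three numbers. The nearest number, that of compound 2, lies within the scatter of compound 3, so no order between compound 3 and compound 2 can be read from these two values. The number of compound 1 lies beyond the scatter below that of compound 3. Going by the values given here, the three measured compounds differ from one another in more than one place, so no single-change step is available among them.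

Compound 4 `Cc1cc2nn(-c3ccc(Cl)cc3)c(C)c2c(=O)o1` differs from compound 3 in one place: chloro in place of hydrogen on an aromatic carbon. Nothing measured here speaks to this change on its own. In this assay the expected step is small, not beyond the scatter, and if anything slightly upward; the estimate for compound 4 means a step of a number 2.5 percentage points higher from compound 3 to compound 4 (within the scatter). Compound 4 is therefore expected to give about 55% in this assay, with a range from 40% to 70%.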

Compound 4, a percentage reported as inhibition, in the whole organism at one dose (the size of the read-out at that dose, not a potency): 56.6%
Estimate against measurement, compound 4: 1.6 percentage points below; the range from low to high includes it.
By their numbers in this assay, from the lowest: compounds 1, 2, 3 and 4 (each within the scatter of the next, the first and the last beyond it).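

In this assay, the series now has its first single-change step: chloro in place of hydrogen, on an aromatic carbon of a six-membered aromatic ring of carbon only, para to a large group, gives a number 4.1 percentage points higher from compound 3 to compound 4 (within the scatter). Because this step lies within the scatter, the read-out does not separate chloro from hydrogen at this place, so the position accepts the chloro group without a loss that can be read, and no gain can be claimed for it either. No measurement here bears on the reason for this step.

Still open, on these data alone, is whether another group at the same place, such as an amine, a carboxylic acid or a longer chain such as propyl, would move the read-out beyond the scatter, and whether chloro would behave in the same way on a different carbon of this ring. Also open, as far as these compounds go, is how compound 3 and compound 4 would compare at other doses or times, since the present values describe the size of the effect at a single dose and a single time and say nothing of potency.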